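Arylthio and sulfonyl enones against DU-145 growth

A few compounds are considered here, and "the series" means these few. Any claim that something is new, unique, unknown or untested is made for them only; others in the source may bear on it.

Measured compounds:
compound 1 `Cc1ccc(S/C(=C/c2ccc(Br)cc2)C(=O)c2ccc(Cl)cc2)cc1`, 25000 nM
compound 2 `Cc1ccc(S/C(=C/c2sccc2C)C(=O)c2ccc(Cl)cc2)cc1`, 50000 nM
compound 3 `Cc1ccsc1/C=C(\C(=O)c1ccc(Cl)cc1)S(=O)(=O)Cc1ccc(F)cc1`, 10000 nM

All three were run in a functional assay on DU-145 cells (Homo sapiens) for inhibition, read by trypan blue exclusion, with a stated time of 96 h; a lower number here means a stronger inhibitor of growth, a higher number a weaker inhibitor of growth. Compound 2 and compound 1 share one core and differ in one place: 4-bromophenyl in place of 3-methylthiophen-2-yl on a double-bonded chain carbon bound to a double-bonded chain carbon. This gave a 2.0-fold lower number from compound 2 to compound 1 (0.30 log units; within the scatter), so on that core the two values cannot be told apart.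

Compound 3 stands on a different core; how the core of compound 3 differs from the core of compound 2 is not broken down here. In this assay compound 3 gives the lowest of the three numbers, and its distance to compound 1 and to compound 2 is beyond the scatter in both cases.

Compound 4 `O=C(/C(=C\c1ccc(Br)cc1)S(=O)(=O)Cc1ccc(F)cc1)c1ccc(Cl)cc1` has not yet been measured in this assay. It stands to compound 3 exactly as compound 1 stands to compound 2: 4-bromophenyl in place of 3-methylthiophen-2-yl on a double-bonded chain carbon bound to a double-bonded chain carbon. The place is the same in both pairs, so this is the same change, seen a second time on the other core.

Going by the values given here, the only guide to its size is the earlier pair. Because a 2.0-fold lower number from compound 2 to compound 1 (0.30 log units; within the scatter) stayed within the scatter, the expectation is a step of similar, small size for compound 4, with no firm direction. For compound 4 the estimated step is a 1.7-fold lower number from compound 3 to compound 4 (0.22 log units; within the scatter). Compound 4 is expected to give about 6000 nM, with the likely range from 2500 nM to 14000 nM.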

Compound 4, concentration for 50% growth inhibition: > 100000 nM
Compound 4 ended at the assay's limit (the forecaster's own chance of this, stated with the estimate: 5%); middle value at least 16-fold (1.22 log units) away from the limit.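

In this assay compound 4 gives > 100000 nM, which is a limit of the assay and not a number. The replacement of 3-methylthiophen-2-yl by 4-bromophenyl gives an at least 10-fold higher number from compound 3 to compound 4 (1.00 log units; beyond the scatter) on the core of compound 3, so in this series the result on one core does not carry over to the other, and the two steps differ: the same change on two cores in this assay, a 2.0-fold lower number (0.30 log units; within the scatter) from compound 2 to compound 1 and an at least 10-fold higher number (1.00 log units; beyond the scatter) from compound 3 to compound 4, at least 20-fold (1.30 log units) apart, beyond the scatter of two such steps This rests on a single pair per core and does not show which feature of the two cores separates the outcomes, nor how large the step on the core of compound 3 really is, with the upper end bounded only by the assay limit: the limit of > 100000 nM in this assay, at which 1 of the 4 values shown sits.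

The compounds shown leave open which part of the difference between the cores goes with the change, since the core of compound 3 differs from the core of compound 2 in more than the sulfonyl group alone, and a pair changing only one of those features on the same core would be needed to separate them. They also leave open how groups such as an amine or a carboxylic acid would behave in place of 3-methylthiophen-2-yl on either core.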